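Series notes: aryl exchange on the aromatic nitrogen

The source may report more compounds than this note shows. Statements on the series, on what has been measured and on what is new or still open speak of the compounds shown alone.

Three members of the series have been measured in a functional assay on HepG2 cells (Homo sapiens) for inhibition, read by sulforhodamine B assay, with a stated time of 72 h, tested at 10 uM; a higher number here means more inhibition at the concentration tested (going by the name of the read-out), a lower number less inhibition. Compound 1 `C[C@H](Nc1ncnc2[nH]cnc12)c1nn(-c2ccncc2)c2cc(F)ccc12` gives 47%, the highest of the three numbers. Compound 3 `C[C@H](Nc1nc(N)nc(N)c1C#N)c1nn(-c2cccnc2)c2cc(C(F)(F)F)ccc12` gives 36%, the nearest to compound 1 yet lower by more than the scatter. Compound 2 `C[C@H](Nc1ncnc2[nH]cnc12)c1nn(-c2cccnc2)c2ccc(F)cc12` gives 8%, the furthest below compound 1, again beyond the scatter.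

Compound 4 `C[C@H](Nc1ncnc2[nH]cnc12)c1nn(-c2cc(F)cc(F)c2)c2cc(F)ccc12` has not been measured. It differs from compound 1 by 3,5-difluorophenyl in place of pyridin-4-yl on an aromatic nitrogen. Going by the values given here, no measured pair in the set shares this kind of change, so its size is not anchored by data. The step of a number 7 percentage points lower from compound 1 to compound 4 (within the scatter) is expected to be small, likely within the scatter or a modest loss, with wide uncertainty. Compound 4 is expected to give 40%, within a range from 15% to 65%.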

Compound 4, a percentage reported as inhibition, at one concentration (the size of the read-out at that concentration, not a potency): 30%
Beside the measured number, compound 4's estimate is 10 percentage points above it, within the range that was stated.
By their numbers in this assay, from the lowest: compound 2; then compounds 4 and 3 (each within the scatter of the next); then compound 1.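

In this assay, 3,5-difluorophenyl in place of pyridin-4-yl on the aromatic nitrogen gives a number 17 percentage points lower from compound 1 to compound 4 (beyond the scatter). Going by these compounds alone, this is the first single-place step, and it shows that this position responds to the aryl exchange, while an aryl ring of carbon only still keeps part of the inhibition. Nothing measured accounts for the step.

Within the data shown here, the single step does not separate losing the ring nitrogen from gaining the two fluorines. Plain phenyl on this nitrogen would bear on that, and how an aminopyridine would read there also stays open.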